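Chloro at the Phenyl of a Pyrazoline Sulfonamide

The source may hold more compounds than are shown below. What is called first, only, known or untested is meant among the compounds shown, and "the series" means these compounds.

Measured so far:
compound 1, `NS(=O)(=O)c1ccc(N2N=C(c3cccc(O)c3)C[C@H]2c2ccccc2)cc1`, 77.7%;
compound 2, `COc1ccc([C@@H]2CC(c3cccc(O)c3)=NN2c2ccc(S(N)(=O)=O)cc2)cc1`, 62.9%.

In a functional assay on the whole organism (strain Wistar albino) for inhibition, with Rattus norvegicus as the target, read by paw edema, with stated times of 30 min and 5 h, at a dose of 0.05 mmol/kg (a lower number here means less inhibition, a higher number more inhibition at the dose given (going by the name of the read-out)), compound 1 stands highest of the two numbers, with compound 2 a step away: a number 14.8 percentage points lower from compound 1 to compound 2 (beyond the scatter). Compound 3, `NS(=O)(=O)c1ccc(N2N=C(c3cccc(O)c3)C[C@H]2c2ccccc2Cl)cc1`, differs from compound 1 by chloro in place of hydrogen on an aromatic carbon. Among the measured compounds shown here, no measured step places a chloro there; the one step known concerns a methoxy at a different carbon, so it bears only loosely. Compound 3 is therefore expected to sit near compound 1, the step estimated as a number 3.7 percentage points lower from compound 1 to compound 3 (within the scatter), likely within the scatter. For compound 3 the estimate is 74%, between 60% and 86%.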

Compound 3, a percentage reported as inhibition, in the whole organism at one dose (the size of the read-out at that dose, not a potency): 70.3%
For compound 3 the middle estimate is 3.7 percentage points above the measured one; the measured number falls inside the stated range.
By their numbers in this assay, from the lowest: compounds 2, 3 and 1 (each within the scatter of the next, the first and the last beyond it).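

In this assay, chloro on the phenyl, ortho to a large group, gives a number 7.4 percentage points lower from compound 1 to compound 3 (within the scatter) and so stays close to the unsubstituted compound, while the methoxy of compound 2 gave a number 14.8 percentage points lower from compound 1 to compound 2 (beyond the scatter) on the same reading. The other listed step, a number 7.4 percentage points higher from compound 2 to compound 3 (within the scatter) for 2-chlorophenyl in place of 4-methoxyphenyl, leaves compound 3 unseparated from either neighbour. Nothing measured here speaks to a cause for these steps. On these data alone, whether an amine or a carboxylic acid on this carbon would hold the number remains open, as does chloro on another carbon of this phenyl.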